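This account rests on a few compounds, and the source may have more. Where it says the series, first, only, none or still open, it means among the compounds named here.

Measured compounds:
compound 1, `Nc1scc(-c2ccc(F)cc2)c1C(=O)c1ccccc1`, 51% in a functional assay on CHO cells for agonist activity at adenosine receptor A1 (Homo sapiens), read by fluorescence and ERK phosphorylation, with stated times of 30 min and 1.5 h, tested at 3 uM; a lower number here means a weaker effect, a higher number a stronger effect of the compound at the concentration tested
compound 2, `Nc1scc(-c2ccccc2)c1C(=O)c1ccc(Cl)cc1`, 51%
compound 3, `Nc1scc(-c2cccc(F)c2)c1C(=O)c1ccc(Cl)cc1`, 76%

Compound 3 gives the highest of the three numbers; compound 1 and compound 2 both sit lower, each beyond the scatter, and the two of them are within the scatter of each other. Among the compounds with values here, the only single-point step that can be traced is a number 25 percentage points higher from compound 2 to compound 3 (beyond the scatter), which puts a fluorine onto the phenyl that sits on the five-membered ring.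

Compound 4, `Nc1scc(-c2ccc(F)cc2)c1C(=O)c1ccc(Cl)cc1`, is not yet measured. It differs from compound 3 by 4-fluorophenyl in place of 3-fluorophenyl on an aromatic carbon. The same atoms are present; only the fluorine has moved on that phenyl ring. Within the data shown here, no measured step tests this move directly. Compound 1 already carries a 4-fluorophenyl on the shared core and gives 51%, no higher than compound 2, which carries a plain phenyl. So the gain seen in the step to compound 3 cannot be assumed to carry over to the 4-fluorophenyl. Compound 4 is therefore expected to fall back toward the level of compound 1 and compound 2, with a step of a number 18 percentage points lower from compound 3 to compound 4 (beyond the scatter), though the range is wide. Estimate for compound 4: 58%, between 40% and 78%.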

Compound 4, a percentage reported as activity, at one concentration (the size of the read-out at that concentration, not a potency): 62%
For compound 4 the middle estimate is 4 percentage points below the measured one, and the stated range covers the measured number.
By their numbers in this assay, from the lowest: compounds 1 and 2 (each within the scatter of the next); then compound 4; then compound 3.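

In this assay, within the data shown here, the position of the fluorine on the phenyl group matters, a point the earlier compounds could not show: exchanging 3-fluorophenyl for 4-fluorophenyl on the aromatic carbon of the five-membered ring gives a number 14 percentage points lower from compound 3 to compound 4 (beyond the scatter). The 4-fluorophenyl is still not equivalent to plain phenyl when the chloro group is present, as there is a number 11 percentage points higher from compound 2 to compound 4 (beyond the scatter), and the chloro group itself now has a readable effect with 4-fluorophenyl in place, with a number 11 percentage points higher from compound 1 to compound 4 (beyond the scatter). No measurement in hand explains why either the fluorine position or the chloro group changes the read-out.

The compounds shown leave open whether the advantage of 3-fluorophenyl persists without the chloro group, and whether a methoxy group, a nitrile or a carboxylic acid at the same place on the phenyl ring would give a higher or lower number. Each compound is read at a single concentration, so these numbers show only a stronger or weaker effect at that concentration, and a full concentration series would be needed to say more.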